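A few compounds are considered here, and "the series" means these few. Any claim that something is new, unique, unknown or untested is made for them only; others in the source may bear on it.

Measured compounds:
- Compound 1 `COc1cc(-c2nnc3n2NC(c2ccco2)C(C(=O)C2CC2)S3)cc(OC)c1OC`: in a functional assay on A549 cells (Homo sapiens) for cytotoxicity, read by MTT assay, with a stated time of 48 h (on this read-out higher numbers stand for weaker inhibition and lower numbers for stronger inhibition), compound 1 gives > 100000 nM, which is a limit of the assay and not a number.
- Compound 2 `COc1cc(-c2nnc3n2NC(c2ccco2)C(C(=O)c2ccccc2F)S3)cc(OC)c1OC`: in this assay compound 2 gives 78700 nM.
- Compound 3 `COc1cc(-c2nnc3n2NC(c2ccco2)C(C(=O)c2ccc(-c4ccccc4)cc2)S3)cc(OC)c1OC`: in this assay compound 3 gives > 100000 nM, again a limit of the assay.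

Compound 3 therefore stands only at a limit, as does compound 1, which is the situation summed up by the limit of > 100000 nM in this assay, at which 2 of the 3 values shown sit. Of the measured steps, an at least 1.2-fold higher number from compound 2 to compound 3 (0.10 log units; that floor lies within the scatter) and a step that the two limits leave unreadable from compound 1 to compound 3 touch compound 3 directly; the first is a floor within the scatter, the second cannot be read. The remaining step, an at least 1.2-fold lower number from compound 1 to compound 2 (0.10 log units; that floor lies within the scatter), is likewise a floor within the scatter. Every change so far swaps the group on the carbonyl carbon, and no step beyond the scatter has appeared.

Compound 4 `COc1cccc(C(=O)C2Sc3nnc(-c4cc(OC)c(OC)c(OC)c4)n3NC2c2ccco2)c1` is the next member, not yet measured. The change is 3-methoxyphenyl in place of 4-phenylphenyl on a carbonyl carbon. It returns to a single six-membered aromatic ring on the carbonyl carbon, as in compound 2, whose value in this assay is 78700 nM. No step beyond the scatter is expected; the expected step of an at least 1.1-fold lower number from compound 3 to compound 4 (0.04 log units; that floor lies within the scatter) is small, with a fair chance that only a limit is reported again. Compound 4 is estimated at 90000 nM, within 40000 nM to 250000 nM.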

Compound 4, half-maximal inhibitory concentration: > 100000 nM
Compound 4 ended at the assay's limit (the forecaster's own chance of this, stated with the estimate: 55%); middle value at least 1.1-fold (0.04 log units) from the limit.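

Shortening 4-phenylphenyl to 3-methoxyphenyl on the carbonyl carbon does not move the series off the limit, so the second aromatic ring of compound 3 is not required for a compound to sit there: compound 4 carries only one such ring. Among the compounds shown here, the single readable step is an at least 1.2-fold higher number from compound 2 to compound 4 (0.10 log units; that floor lies within the scatter), so 3-methoxyphenyl and 2-fluorophenyl cannot be told apart in this assay. The steps from compound 3 to compound 4 and from compound 1 to compound 4 cannot be read, and most of the series now rests at one limit: the limit of > 100000 nM in this assay, at which 3 of the 4 values shown sit.

From the compounds shown here alone, whether any group on this carbonyl carbon gives a value clearly away from that limit remains open. An amine or a carboxylic acid at this place, in particular, remains untested in the compounds shown here.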